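Two limits ahead of compound 3

The source may report more compounds than this note shows. Statements on the series, on what has been measured and on what is new or still open speak of the compounds shown alone.

Values so far in a functional assay on MDA-MB-231 cells (Homo sapiens) for antiproliferative activity, read by MTT assay, with a stated time of 24 h; on this read-out lower numbers stand for stronger inhibition and higher numbers for weaker inhibition:
- Compound 1 `CCCCc1oc2ccccc2c1C(=O)c1ccc(OCC(=O)N2CCCCC2)cc1` gives > 50000 nM as a limit
- Compound 2 `CCCCc1oc2ccccc2c1C(=O)c1ccc(OCC(=O)Nc2cccc(OC)c2)cc1` gives > 50000 nM as a limit

Compound 2 reads > 50000 nM which is a limit of the assay and not a number. Compound 1 reads > 50000 nM which is likewise a limit. Among the measured compounds shown here, the series so far therefore shows only the limit of > 50000 nM in this assay, at which 2 of the 2 values shown sit, and offers no number to build on.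

Compound 3 `CCCCc1oc2ccccc2c1C(=O)c1ccc(OCCCC(=O)N2CCOCC2)cc1` has not yet been measured. Its difference from compound 2 is 2-((morpholin-4-yl)carbonyl)ethyl in place of (3-methoxyphenyl)carbamoyl on a saturated chain carbon bound to an oxygen on an aromatic ring and it puts 2-((morpholin-4-yl)carbonyl)ethyl in place of (3-methoxyphenyl)carbamoyl on a saturated chain carbon bound to an oxygen on an aromatic ring.

For the measured compounds named here, the only measured step that bears on this is a step that the two limits leave unreadable from compound 1 to compound 2 and it gives no size to carry forward. With that step unreadable, no shift beyond the scatter is expected in this assay and neither direction is favoured. The expected move is a number no higher from compound 2 to compound 3 (the limit leaves the size open) and another limit reading is the likeliest outcome. Compound 3 is estimated at 50000 nM with an expected range from 20000 nM to 120000 nM in this read-out.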

Compound 3, half-maximal inhibitory concentration: 31600 nM
For compound 3 the middle estimate is 1.6-fold (0.20 log units) above the measured one, and the stated range covers the measured number.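

Among the compounds shown here, with compound 3, this place on a saturated chain carbon bound to an oxygen on an aromatic ring yields a number for the first time, as compound 3 gives 31600 nM in this assay. Placing 2-((morpholin-4-yl)carbonyl)ethyl there in place of (3-methoxyphenyl)carbamoyl gives an at least 1.5-fold lower number from compound 2 to compound 3 (0.19 log units; that floor lies within the scatter), and placing it there in place of (piperidin-1-yl)carbonyl gives an at least 1.5-fold lower number from compound 1 to compound 3 (0.19 log units; that floor lies within the scatter). Both steps are floors rather than measured sizes, and the step between the two earlier compounds cannot be read, so the series still rests largely on one assay limit: the limit of > 50000 nM in this assay, at which 2 of the 3 values shown sit.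

The compounds shown leave open whether any real difference from compound 1 belongs to the morpholine ring or to the chain that carries it, since the step changes both at once. They also leave open how a carboxylic acid or a longer chain at this place would read in this assay, and whether any such group would bring the number clearly beyond the usual scatter of compound 3.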